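From Methyl to Butoxy in a Level Series

This account rests on a few compounds, and the source may have more. Where it says the series, first, only, none or still open, it means among the compounds named here.

In a functional assay on DLD-1 cells (Homo sapiens) for cytotoxicity, with a stated time of 48 h (on this read-out lower numbers stand for stronger inhibition and higher numbers for weaker inhibition), compound 1 `CCCCCOc1ccc2oc(/C=C/[S+](C)[O-])cc(=O)c2c1` gives 6600 nM as its reading, compound 2 `C[S+]([O-])/C=C/c1cc(=O)c2ccccc2o1` gives 8000 nM as its reading, and compound 3 `Cc1ccc2oc(/C=C/[S+](C)[O-])cc(=O)c2c1` gives 7000 nM on the same read-out. Compound 3 stands level with both others, since its gaps to them lie within the scatter of repeated measurements. Compound 4 `CCCCOc1ccc2oc(/C=C/[S+](C)[O-])cc(=O)c2c1` keeps the shared core and carries butoxy in place of methyl on an aromatic carbon. Among the compounds with values here, three measured steps bear on this change. Methyl in place of pentyloxy, the closest comparison, gave a 1.1-fold higher number from compound 1 to compound 3 (0.03 log units; within the scatter) and hydrogen in place of pentyloxy gave a 1.2-fold higher number from compound 1 to compound 2 (0.08 log units; within the scatter) while methyl in place of hydrogen gave a 1.1-fold lower number from compound 2 to compound 3 (0.06 log units; within the scatter) on the same core. All three stayed within the scatter, so no step beyond it is expected in this assay for this swap. The expected step is a 1.0-fold lower number from compound 3 to compound 4 (0.01 log units; within the scatter) and nothing larger. The estimated value for compound 4 is 6800 nM with an expected range from 3500 nM to 13000 nM once measured.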

Compound 4, half-maximal inhibitory concentration: 4800 nM
Compound 4: the middle estimate sits 1.4-fold (0.15 log units) above what was measured; the measured number falls inside the stated range.
By their numbers in this assay, from the lowest: compounds 4, 1, 3 and 2 (each within the scatter of the next).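

In this assay butoxy is a fourth group on this aromatic carbon, and the reading again stays level: butoxy in place of methyl gives a 1.5-fold lower number from compound 3 to compound 4 (0.16 log units; within the scatter) and butoxy in place of hydrogen gives a 1.7-fold lower number from compound 2 to compound 4 (0.22 log units; within the scatter) while shortening pentyloxy to butoxy gives a 1.4-fold lower number from compound 1 to compound 4 (0.14 log units; within the scatter) on the same core. The step from hydrogen to butoxy is the largest seen so far in this series, yet it too stays within the scatter, so among these four compounds neither adding a group at this carbon nor changing its chain length separates the readings. No measurement shown here offers an explanation for this flat picture.

An amine or a carboxylic acid on this carbon could behave differently, and so could a chain longer than pentyloxy. The compounds shown also leave open whether a group on another part of the shared core would shift the reading beyond the scatter.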